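Hydroxyphenyl placement on the shared core and topoisomerase inhibition

A few compounds are considered here, and "the series" means these few. Any claim that something is new, unique, unknown or untested is made for them only; others in the source may bear on it.

Measured so far:
compound 1, `Oc1cccc(-c2cc(-c3ccccn3)cc(-c3ccccc3O)n2)c1`, 35.4%
compound 2, `Oc1ccc(-c2cc(-c3ccccn3)cc(-c3ccccc3O)n2)cc1`, 0.2%
compound 3, `Oc1cccc(-c2cc(-c3ccccn3)cc(-c3cccc(O)c3)n2)c1`, 8.3%

In an assay on isolated protein for inhibition of DNA topoisomerase 1 (Homo sapiens), with a stated time of 30 min, tested at 100 uM (a lower number here means a weaker effect, a higher number a stronger effect of the compound at the concentration tested), compound 1 gives the highest of the three numbers. The move 4-hydroxyphenyl in place of 3-hydroxyphenyl on an aromatic carbon brings a number 35.2 percentage points lower from compound 1 to compound 2 (beyond the scatter). The move 3-hydroxyphenyl in place of 2-hydroxyphenyl on an aromatic carbon brings a number 27.1 percentage points lower from compound 1 to compound 3 (beyond the scatter). The values of compound 2 and compound 3 lie within the usual scatter of each other, so no order between them is claimed.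

Compound 4, `Oc1ccc(-c2cc(-c3ccccn3)cc(-c3cccc(O)c3)n2)cc1`, has not been measured. It differs from compound 3 by 4-hydroxyphenyl in place of 3-hydroxyphenyl on an aromatic carbon. This is the same kind of change as from compound 1 to compound 2, though the surroundings differ: there the place was meta to a 2-hydroxyphenyl group, here it is meta to a 3-hydroxyphenyl group. The two cores differ by 3-hydroxyphenyl in place of 2-hydroxyphenyl on an aromatic carbon.

Compound 3 already sits low in this assay, so the estimated step of a number 6.3 percentage points lower from compound 3 to compound 4 (within the scatter) is expected to be much smaller than a number 35.2 percentage points lower from compound 1 to compound 2 (beyond the scatter), since compound 3 gives 8.3% and the read-out has little room left to fall. Compound 4 is expected to give 2%, within 0% to 12%.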

Compound 4, a percentage reported as inhibition, at one concentration (the size of the read-out at that concentration, not a potency): 2.4%
Beside the measured number, compound 4's estimate is 0.4 percentage points below it; measured number inside the range.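

In this assay, 4-hydroxyphenyl in place of 3-hydroxyphenyl brings a number 5.9 percentage points lower from compound 3 to compound 4 (within the scatter), so the large fall seen on the other core does not carry over in size: the same change on two cores in this assay, a number 35.2 percentage points lower (beyond the scatter) from compound 1 to compound 2 and a number 5.9 percentage points lower (within the scatter) from compound 3 to compound 4, 29.3 percentage points apart, beyond the scatter of two such steps. Likewise, 3-hydroxyphenyl in place of 2-hydroxyphenyl brings a number 2.2 percentage points higher from compound 2 to compound 4 (within the scatter), which again does not match the same change on the other core: the same change on two cores in this assay, a number 27.1 percentage points lower (beyond the scatter) from compound 1 to compound 3 and a number 2.2 percentage points higher (within the scatter) from compound 2 to compound 4, 29.3 percentage points apart, beyond the scatter of two such steps. With 4-hydroxyphenyl in place of 2-hydroxyphenyl bringing a number 33 percentage points lower from compound 1 to compound 4 (beyond the scatter), compound 1 alone stands apart from the other three, but readings this close to zero at a single concentration do not show whether the changes truly have no effect on these cores or the read-out simply has no room left to fall.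

The compounds shown leave open whether the higher number of compound 1 needs both of its hydroxyl groups, and how a methoxy group or an amine would read in place of either one. On these data alone, the pyridin-2-yl group is the same in all four compounds, so its contribution also remains open.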